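Amide heteroaryl swap in sulfonylbenzylamide series

The source may report more compounds than this note shows. Statements on the series, on what has been measured and on what is new or still open speak of the compounds shown alone.

Measured in a functional assay on A2780 cells (Homo sapiens) for inhibition, read by sulforhodamine B assay, with a stated time of 72 h; a lower number here means a stronger inhibitor, a higher number a weaker inhibitor:
compound 1 `O=C(NCc1ccc(S(=O)(=O)N2CCCCC2)cc1)c1cc2ccncc2[nH]1`: 1700 nM
compound 2 `O=C(NCc1ccc(S(=O)(=O)c2ccccc2)cc1)c1cc(-c2cccnc2)no1`: > 10000 nM
compound 3 `O=C(NCc1ccc(S(=O)(=O)c2ccc(F)cc2)cc1)c1cc2cnccc2[nH]1`: 16 nM

Compound 1 gives the highest of the two numbers in this assay; compound 3 stands much lower, a gap well beyond the usual scatter. Compound 2 reaches only the limit of the assay, (the limit of > 10000 nM in this assay, at which 1 of the 3 values shown sits), which is a bound and not a number.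

Compound 4 `O=C(NCc1ccc(S(=O)(=O)N2CCCCC2)cc1)c1cc2cccnc2s1` has not yet been measured. It differs from compound 1 in one place: a group of 9 heavy atoms (7 carbon, 1 nitrogen, 1 sulfur; one five-membered aromatic ring with 1 hetero atom, one six-membered aromatic ring with 1 hetero atom) in place of a group of 9 heavy atoms (7 carbon, 2 nitrogen; one five-membered aromatic ring with 1 hetero atom, one six-membered aromatic ring with 1 hetero atom), on a carbonyl carbon. For the measured compounds named here, no pair of measured compounds differs in only that place, so the size of this step cannot be read from the data. Compound 3 changes both the group on the sulfonyl and the group on the carbonyl carbon, so its value is not a step from compound 1.

For compound 4 the expectation is a modest weakening, a 2.4-fold higher number from compound 1 to compound 4 (0.37 log units; beyond the scatter), with a fair chance of only a limit. The estimate for compound 4 in this assay is 4000 nM, with a range from 1000 nM to 15000 nM.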

Compound 4, half-maximal inhibitory concentration: > 10000 nM
Compound 4 gave a limit, no number (the forecaster's own chance of this, stated with the estimate: 30%); middle value at least 2.5-fold (0.39 log units) away from the limit.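

Holding the rest of compound 1 fixed, the group on the carbonyl carbon clearly matters in this assay: the swap gives an at least 5.8-fold higher number from compound 1 to compound 4 (0.76 log units; beyond the scatter). Compound 4 stands at a limit of the assay, not a number: the limit of > 10000 nM in this assay, at which 2 of the 4 values shown sit.
The step therefore gives only a minimum size, and since the entering group has 0 hydrogen-bond donors where the leaving group has 1, while sulfur also enters, this single swap cannot separate the two changes.

Still open, going by these compounds, is whether an oxygen in place of the sulfur, or a methyl group on the nitrogen that carries the hydrogen-bond donor, would give a number in this assay. Also open, on these data alone, is whether the same swap would cost as much on the sulfonyl group of compound 3, a step that cannot be read from these compounds.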